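Halogen Swap on the Aryl Amine of Compound 3

The compounds below may be only part of what the source reports. "The series", "measured", "known", "first", "only" and "open" are said of these compounds alone.

Compound 1 `O=C(CSc1nc(Nc2ccccc2)c2ccccc2n1)Nc1ccc(Br)cc1` gives 19300 nM in a functional assay on MGC-803 cells (Homo sapiens) for inhibition, read by MTT assay, with a stated time of 72 h; on this read-out lower numbers stand for stronger inhibition and higher numbers for weaker inhibition.
Compound 2 `O=C(CSc1nc(Nc2ccccc2)c2ccccc2n1)Nc1ccc(Cl)c(Cl)c1` gives 37900 nM in this assay.
Compound 3 `C=CC(=O)Nc1cccc(NC(=O)CSc2nc(Nc3cccc(F)c3)c3ccccc3n2)c1` gives 6250 nM in this assay.

Among these three numbers, compound 3 stands lowest, that is, as the strongest inhibitor: compound 1 sits higher by a gap beyond the scatter, and compound 2 higher still, also beyond the scatter. Among the measured compounds shown here, only one pair of measured compounds differs in a single place, and that step, a 2.0-fold higher number from compound 1 to compound 2 (0.29 log units; within the scatter), exchanges the group on the amide-type nitrogen; it lies within the scatter, so it counts as no real change.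

Compound 4 `C=CC(=O)Nc1cccc(NC(=O)CSc2nc(Nc3ccc(Cl)cc3Cl)c3ccccc3n2)c1` differs from compound 3 elsewhere: 2,4-dichlorophenyl in place of 3-fluorophenyl on a nitrogen on an aromatic ring. For the measured compounds named here, no measured step touches that nitrogen, so there is no direct precedent for this exchange. Going by the values given here, the one halogen-for-halogen swap that has been measured, on the other nitrogen, moved the number only within the scatter. On that thin basis the step of a 1.3-fold higher number from compound 3 to compound 4 (0.11 log units; within the scatter) is expected to stay small, with no confident direction. Compound 4 is therefore estimated at 8000 nM in this assay, with a range from 2500 nM to 25000 nM that reflects how little the measured compounds say about this position.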

Compound 4, half-maximal inhibitory concentration: 12100 nM
The estimate for compound 4 lay 1.5-fold (0.18 log units) below the measured number, within the range that was stated.
By their numbers in this assay, from the lowest: compounds 3, 4, 1 and 2 (each within the scatter of the next, the first and the last beyond it).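

Among the compounds shown here, this is the first measured exchange on the nitrogen on an aromatic ring, and the step of a 1.9-fold higher number from compound 3 to compound 4 (0.29 log units; within the scatter) counts as no real change in this assay. With the rest of the molecule held constant, 3-fluorophenyl (7 heavy atoms, one fluorine) can therefore give way to 2,4-dichlorophenyl (8 heavy atoms, two chlorines) without a reading that stands apart from the usual scatter, so this pair shows that the position accepts this particular halogen change. Nothing available explains why the number holds, and the result is a plain observation about these two compounds.

For the compounds shown here, the pair covers only two halogen-bearing phenyl groups at this nitrogen, so it cannot show whether the two chlorines each matter or whether their contributions simply offset one another. It also leaves open whether a phenyl ring carrying an amine or a carboxylic acid, or a longer alkyl chain in place of the ring, would move the number beyond the scatter.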